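Piperazinyl replaces a mesylate-type leaving group on a fused core

The compounds below may be only part of what the source reports. "The series", "measured", "known", "first", "only" and "open" are said of these compounds alone.

The series rests on a shared core carrying a bromo group and a benzylic amide. Compound 1 `N[C@H]1CC[C@H](Nc2c(C(=O)NCc3ccc(Cl)cc3)nc(Br)c3cccnc23)CC1` bears a cyclohexyl diamine on that core and a chlorobenzyl amide; in a functional assay on MCF7 cells (Homo sapiens) for cytotoxicity, read by MTT assay, with a stated time of 72 h (on this read-out higher numbers stand for weaker inhibition and lower numbers for stronger inhibition), compound 1 gives "not determined" (no result reported), that is, no result reported. Within the data shown here, compound 3 `N[C@H]1CC[C@H](Nc2c(C(=O)NCc3ccccn3)nc(Br)c3cccnc23)CC1` keeps the same diamine and carries a pyridylmethyl amide; in this assay compound 3 gives 15000 nM, the only number in this set. Compound 2 `CS(=O)(=O)Oc1c(C(=O)NCc2ccc(F)cc2)nc(Br)c2cccnc12` carries a fluorobenzyl amide and a (methylsulfonyl)oxy group on the core; in this assay compound 2 gives "not determined" (no result reported), likewise without a number, so no comparison of it with compound 3 can be made on the figures shown.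

Compound 4 `O=C(NCc1ccc(F)cc1)c1nc(Br)c2cccnc2c1N1CCNCC1` differs from compound 2 in one place: piperazin-1-yl in place of (methylsulfonyl)oxy on an aromatic carbon

Among the measured compounds shown here, no step between measured compounds is available to anchor this change, and compound 2 itself offers no number. For the measured compounds named here, the only guidance is compound 3, whose reading of 15000 nM in this assay marks the level at which an amine on this core has so far been seen. Compound 4 is therefore expected to sit in a similar weak range in this assay, estimated at 20000 nM, with a plausible span from 5000 nM to 80000 nM, and a fair chance that only a limit is reported.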

Compound 4, half-maximal inhibitory concentration: 7000 nM
Estimate against measurement, compound 4: 2.9-fold (0.46 log units) above; the measured number falls inside the stated range.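

Compound 2 gives "not determined" (no result reported) in this assay and so the change from it to compound 4 cannot be read as a step. No supporting evidence bears on the result for compound 4. Left open is how piperazin-1-yl and (methylsulfonyl)oxy compare at this place on the shared core in this assay when both carry the same fluorobenzyl amide.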